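From a chloro-fluoro ring to a difluoromethoxy ring

The source may report more compounds than this note shows. Statements on the series, on what has been measured and on what is new or still open speak of the compounds shown alone.

Compound 1 `OC[C@H]1O[C@@H](n2cnc3c(NCc4ccc(F)cc4F)ncnc32)[C@H](O)[C@@H]1O`: 9600 nM
Compound 2 `OC[C@H]1O[C@@H](n2cnc3c(NCc4ccc(F)cc4Cl)ncnc32)[C@H](O)[C@@H]1O`: 15600 nM

Among the measured compounds shown here, in a functional assay on K562 cells (Homo sapiens) for antiproliferative activity, with a stated time of 72 h (on this read-out higher numbers stand for weaker inhibition and lower numbers for stronger inhibition), compound 2 stands level with compound 1, the only other measured compound, as their two values lie within the scatter of each other. Compound 3 `OC[C@H]1O[C@@H](n2cnc3c(NCc4ccccc4OC(F)F)ncnc32)[C@H](O)[C@@H]1O` keeps the shared core but carries a different group on a saturated chain carbon bound to a nitrogen on an aromatic ring: 2-(difluoromethoxy)phenyl in place of 2-chloro-4-fluorophenyl (2-(difluoromethoxy)phenyl in place of 2-chloro-4-fluorophenyl on a saturated chain carbon bound to a nitrogen on an aromatic ring). For the measured compounds named here, the only measured step that bears on this is a 1.6-fold higher number from compound 1 to compound 2 (0.21 log units; within the scatter), with chloro in place of fluoro on an aromatic carbon. Going by the values given here, no measured compound carries the entering group, so this small step is only a loose guide. No change beyond the scatter is therefore expected in this assay, in either direction. The expected step is a 1.3-fold lower number from compound 2 to compound 3 (0.11 log units; within the scatter). For compound 3 the estimated value is 12000 nM, with an expected range from 4000 nM to 36000 nM.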

Compound 3, half-maximal inhibitory concentration: > 166000 nM
Compound 3 gave a limit, no number; the forecaster's own chance of this, stated with the estimate: 15%; middle value at least 13-fold (1.14 log units) away from the limit.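

Compound 3 gives a limit and not a number: the limit of > 166000 nM in this assay, at which 1 of the 3 values shown sits. Even so, the change is large and beyond the scatter, with an at least 10-fold higher number from compound 2 to compound 3 (1.02 log units; beyond the scatter) and an at least 17-fold higher number from compound 1 to compound 3 (1.23 log units; beyond the scatter). The earlier step, a 1.6-fold higher number from compound 1 to compound 2 (0.21 log units; within the scatter), stayed within the scatter, so compounds 1 and 2 alone gave no sign that this place, a saturated chain carbon bound to a nitrogen on an aromatic ring, is sensitive to what it carries, whereas 2-(difluoromethoxy)phenyl shows that it can be.

The compounds shown leave open whether the difference follows from the difluoromethoxy group that enters or from the halogens that leave, as both change in one step. A plain phenyl ring or a phenyl ring with a methoxy group at this place could help separate the two.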